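The source may report more compounds than this note shows. Statements on the series, on what has been measured and on what is new or still open speak of the compounds shown alone.

Notes on the series. Two compounds have entries so far: compound 1 `CC(C)CCn1nc(-c2cccs2)c(O)c(C2=NS(=O)(=O)c3cc(S(=O)(=O)N(C)C)ccc3N2)c1=O` and compound 2 `CCCC(C)n1nc(-c2cccs2)c(O)c(C2=NS(=O)(=O)c3cc(NS(C)(=O)=O)ccc3N2)c1=O`. In an ADME assay on Huh-7 cells (Homo sapiens) for cytotoxicity, with a stated time of 72 h (on this read-out higher numbers stand for lower toxicity in this test and lower numbers for higher toxicity in this test), compound 1 is recorded as "not determined" (no result reported). In this assay compound 2 gives > 33000 nM, which is a limit of the assay rather than a number. Compound 2 thus stands at the limit of > 33000 nM in this assay, at which 1 of the 2 values shown sits. For the measured compounds named here, no step between two measured compounds can be drawn from these two entries.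

The next compound, compound 3 `CS(=O)(=O)Nc1ccc2c(c1)S(=O)(=O)N=C(c1c(O)c(-c3cccs3)nn(Cc3ccccn3)c1=O)N2`, differs from compound 2 by (pyridin-2-yl)methyl in place of 1-methylbutyl on an aromatic nitrogen. Going by the values given here, with no measured step to lean on, the expectation for this assay is a step of no size beyond the scatter, with the reading expected to remain at the limit. Compound 3 is estimated at 33000 nM in this assay, with a range of 15000 nM to 100000 nM. The expected step is a number no higher from compound 2 to compound 3 (the limit leaves the size open).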

Compound 3, half-maximal cytotoxic concentration: > 1000 nM
Compound 3: no number, only a limit; the forecaster's own chance of this, stated with the estimate: 70%; the middle value is on the limit's open side.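

Compound 2 and compound 3 are both recorded only as limits in this assay, and no step can be read between them. The compounds shown leave open whether (pyridin-2-yl)methyl in place of 1-methylbutyl on the aromatic nitrogen changes the half-maximal cytotoxic concentration at all.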